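This account rests on a few compounds, and the source may have more. Where it says the series, first, only, none or still open, it means among the compounds named here.

Measured so far in a functional assay on CCRF-CEM cells (Homo sapiens) for cytotoxicity, with a stated time of 72 h; a lower number here means a stronger inhibitor, a higher number a weaker inhibitor:
Compound 1, `O=C(/C=C/C=C/C=C/c1ccc[nH]1)c1ccccc1`, gives 3070 nM.
Compound 2, `O=C(/C=C/C=C/C=C/C=C/c1ccc[nH]1)c1ccccc1`, gives 720 nM.
Compound 3, `O=C(/C=C/C=C/C=C/c1ccc[nH]1)OCc1ccccc1`, gives 830 nM.

Compounds 1 and 2 share a core and differ at one place: 2-(1H-pyrrol-2-yl)ethenyl in place of 1H-pyrrol-2-yl on a double-bonded chain carbon bound to a double-bonded chain carbon. That change brings a 4.3-fold lower number from compound 1 to compound 2 (0.63 log units; beyond the scatter). Compound 3 has a different core; the difference between the two cores is not broken down here. Its number in this assay sits close to that of compound 2, within the usual scatter, and is lower than that of compound 1 by a gap that lies beyond the scatter.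

Compound 4, `O=C(/C=C/C=C/C=C/C=C/c1ccc[nH]1)OCc1ccccc1`, is not yet measured. It stands to compound 3 as compound 2 stands to compound 1: 2-(1H-pyrrol-2-yl)ethenyl in place of 1H-pyrrol-2-yl on a double-bonded chain carbon bound to a double-bonded chain carbon. The place of the change is described in the same words for both pairs, so the change is of the same kind on a different core. If the lengthening of the chain acts on the core of compound 3 as it did on the core of compound 1, then because of a 4.3-fold lower number from compound 1 to compound 2 (0.63 log units; beyond the scatter) a step of about a 3.2-fold lower number from compound 3 to compound 4 (0.50 log units; beyond the scatter) is expected from compound 3 to compound 4. For the measured compounds named here, with only one prior example, the expected step is kept somewhat smaller. Compound 4 is expected to give about 260 nM in this assay, with a likely range from 100 nM to 700 nM.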

Compound 4, half-maximal inhibitory concentration: 190 nM
Beside the measured number, compound 4's estimate is 1.4-fold (0.14 log units) above it; the range from low to high includes it.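

In this assay, 2-(1H-pyrrol-2-yl)ethenyl in place of 1H-pyrrol-2-yl on the core of compound 3 brings a 4.4-fold lower number from compound 3 to compound 4 (0.64 log units; beyond the scatter). Set beside the earlier step, the same lengthening of the chain gives a step of matching size on both cores: the same change on two cores in this assay, a 4.3-fold lower number (0.63 log units; beyond the scatter) from compound 1 to compound 2 and a 4.4-fold lower number (0.64 log units; beyond the scatter) from compound 3 to compound 4, 1.0-fold (0.01 log units) apart, within the scatter of two such steps. For the compounds shown here, in these two pairs, then, the change carries from one core to the other with its size intact, but this rests on only two pairs in a single cell assay, and it shows neither why the number falls nor that a third core would respond in the same way.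

The compounds shown leave open whether a still longer chain would lower the number further or whether the trend would stop. They also leave open how the series would respond to an amine or a carboxylic acid in place of 1H-pyrrol-2-yl at the end of the chain.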